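Swapping methylsulfanyl for a selenium chain on the shared core

The source may hold more compounds than are shown below. What is called first, only, known or untested is meant among the compounds shown, and "the series" means these compounds.

Compound 3 `CS/C(=N\C(=O)c1ccc(Cl)cc1)NC(=O)c1ccc(Cl)cc1` was tested in a functional assay on PC-3 cells (Homo sapiens) for cytotoxicity, read by MTT assay; on this read-out higher numbers stand for weaker inhibition and lower numbers for stronger inhibition. In this assay compound 3 gives > 10000 nM, which is a limit of the assay and not a number. Compound 4 `CC(C)[Se]/C(=N\C(=O)c1ccc(Cl)cc1)NC(=O)c1ccc(Cl)cc1` differs from compound 3 in one place: a group of 4 heavy atoms (3 carbon, 1 selenium; no ring) in place of a group of 2 heavy atoms (1 carbon, 1 sulfur; no ring), on a carbon with a double bond to nitrogen. The nearest measured comparison is the sulfur-to-selenium change on the other core. Compound 1 `CS/C(=N\C(=O)c1ccc(Cl)nc1)NC(=O)c1ccc(Cl)nc1` in this assay gives > 10000 nM, again a limit. Compound 2 `C[Se]/C(=N\C(=O)c1ccc(Cl)nc1)NC(=O)c1ccc(Cl)nc1` in this assay gives 9140 nM. That step, an at least 1.0-fold lower number from compound 1 to compound 2 (0.03 log units; that floor lies within the scatter), is too small to show a direction, and the limit of > 10000 nM in this assay, at which 2 of the 3 values shown sit, leaves most of this set barely resolved. The step from compound 3 to compound 4 is therefore expected to be small, an at least 1.0-fold lower number from compound 3 to compound 4 (0.02 log units; that floor lies within the scatter). Compound 4 is estimated at 9500 nM, within 4000 nM to 30000 nM.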

Compound 4, half-maximal inhibitory concentration: > 10000 nM
Compound 4 was reported as a limit (the forecaster's own chance of this, stated with the estimate: 55%); at least 1.0-fold (0.02 log units) between middle value and limit.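

In this assay compound 3 and compound 4 both sit at a limit, and no step between them can be read: the limit of > 10000 nM in this assay, at which 3 of the 4 values shown sit.

As far as these compounds go, whether the selenium chain in place of methylsulfanyl changes cytotoxicity on this shared core stays open.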